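The source may hold more compounds than are shown below. What is called first, only, known or untested is meant among the compounds shown, and "the series" means these compounds.

Compound 1 `O=S(=O)(O)OC[C@@H]1O[C@H](OS(=O)(=O)O)[C@H](OS(=O)(=O)O)[C@@H](OS(=O)(=O)O)[C@@H]1OS(=O)(=O)O` gives 37500 nM in an assay on isolated protein with fibroblast growth factor 1 (Homo sapiens) as the target; on this read-out lower numbers stand for tighter binding and higher numbers for weaker binding.
Compound 2 `O=S(=O)(O)OC[C@@H]1O[C@H](O[C@H]2[C@H](OS(=O)(=O)O)[C@H](OS(=O)(=O)O)C(OS(=O)(=O)O)O[C@H]2COS(=O)(=O)O)[C@@H](OS(=O)(=O)O)[C@H](OS(=O)(=O)O)[C@H]1OS(=O)(=O)O` gives 540 nM in this assay.
Compound 3 `CO[C@@H]1CCO[C@H](COS(=O)(=O)O)C1OS(=O)(=O)O` gives 5940000 nM in this assay.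

Of the three numbers measured in this assay, compound 3 stands highest, so it binds weakest of the three. Its gap to compound 1, the nearest of the other two, lies beyond the scatter, and its gap to compound 2, the furthest, lies still further beyond it. Compound 4 `O=S(=O)(O)OC[C@H]1OCC[C@@H](OCCCOc2ccccc2)C1OS(=O)(=O)O` has not yet been measured. It differs from compound 3 in one place: 2-phenoxyethyl in place of hydrogen on a saturated chain carbon bound to an oxygen on a saturated carbon. Among the measured compounds shown here, no measured pair shows the effect of such a change, so the expectation rests on the very weak binding of compound 3 alone. Compound 4 is expected to stay close to compound 3, with a step of a 2.0-fold lower number from compound 3 to compound 4 (0.30 log units; within the scatter) that does not clearly rise above the scatter in either direction. Compound 4 is therefore estimated at about 3000000 nM in this assay, with a range from 500000 nM to 15000000 nM.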

Compound 4, dissociation constant: 3250000 nM
Compound 4: the middle estimate sits 1.1-fold (0.03 log units) below what was measured; measured number inside the range.
By their numbers in this assay, from the lowest: compound 2; then compound 1; then compounds 4 and 3 (each within the scatter of the next).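

Among the compounds shown here, putting 2-phenoxyethyl in place of hydrogen on a saturated chain carbon bound to an oxygen on a saturated carbon gives the first reading of a change at this position: a 1.8-fold lower number from compound 3 to compound 4 (0.26 log units; within the scatter) in this assay. The position therefore takes on 9 heavy atoms and one six-membered aromatic ring of carbon only, with no shift in binding that rises above the scatter. No independent measurement bears on the reason for this result.

The compounds shown leave open whether an amine, a carboxylic acid or a longer chain in this same place would move the number beyond the scatter. Also open, as far as these compounds go, is whether 2-phenoxyethyl would leave the number just as unmoved on the core of compound 2, a compound that binds far more tightly.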